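The source may hold more compounds than are shown below. What is called first, only, known or untested is meant among the compounds shown, and "the series" means these compounds.

Three close relatives of one shared scaffold have been measured, and a fourth awaits its number. Compound 1 `N=C(N)c1ccc(-c2ccc(-c3ccc(F)cc3)o2)o1` and compound 2 `N=C(N)c1ccc(-c2ccc(-c3ccc(Cl)cc3)o2)o1` share the same core and differ in only a single substituent. In a functional assay on UACC-62 cells (Homo sapiens) for inhibition, read by sulforhodamine B assay, with a stated time of 48 h (on this read-out lower numbers stand for stronger inhibition of growth and higher numbers for weaker inhibition of growth), compound 1 gives 1740 nM, while compound 2 gives 1890 nM. The structural change between them is fluoro in place of chloro on an aromatic carbon, and the step it made was a 1.1-fold lower number from compound 2 to compound 1 (0.04 log units; within the scatter).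

Compound 3 `N=C(N)c1ccc(-c2ccc(-c3ccc(Cl)cc3)s2)s1` carries the same chloro group as compound 2 but on a different core; the difference between the two cores is not broken down here. In this assay compound 3 gives 1800 nM, a number that lies within the usual scatter of both compound 1 and compound 2.

Compound 4 `N=C(N)c1ccc(-c2ccc(-c3ccc(F)cc3)s2)s1` has not yet been measured. It relates to compound 3 exactly as compound 1 relates to compound 2: the change is fluoro in place of chloro on an aromatic carbon, the same change at the same kind of position. Because the earlier step was a 1.1-fold lower number from compound 2 to compound 1 (0.04 log units; within the scatter), a similarly small step is expected here, a 1.0-fold lower number from compound 3 to compound 4 (0.01 log units; within the scatter). Compound 4 is therefore expected to give 1750 nM in this assay, with the estimate bounded between 900 nM and 3400 nM. Among the measured compounds shown here, this expectation rests on only one prior example of the change, so it remains provisional.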

Compound 4, concentration for 50% growth inhibition: 1940 nM
For compound 4 the middle estimate is 1.1-fold (0.04 log units) below the measured one, and the stated range covers the measured number.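

In this assay, putting fluoro in place of chloro on the core of compound 3 gives a 1.1-fold higher number from compound 3 to compound 4 (0.03 log units; within the scatter), a step too small to tell apart from repeat-to-repeat noise. Set beside the same swap on the core of compound 1, the two steps agree: the same change on two cores in this assay, a 1.1-fold lower number (0.04 log units; within the scatter) from compound 2 to compound 1 and a 1.1-fold higher number (0.03 log units; within the scatter) from compound 3 to compound 4, 1.2-fold (0.07 log units) apart, within the scatter of two such steps. So on these two cores the swap makes no readable difference to growth inhibition, and the apparent opposite directions of the two steps carry no meaning; this does not show that the swap would be equally silent on a third core, and two pairs with such small steps cannot reveal a small real effect hidden in the scatter.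

The compounds shown carry only chloro or fluoro at this place on the six-membered ring, so it stays open whether a larger or different group there, such as a methoxy group, a nitrile or a carboxylic acid, would shift the number by more than the scatter. On these data alone, it also stays open whether chloro and fluoro would remain interchangeable in other cell lines or with a longer exposure time.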